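A few compounds are considered here, and "the series" means these few. Any claim that something is new, unique, unknown or untested is made for them only; others in the source may bear on it.

Measured so far:
compound 1, `CCN(Cc1cccn1C)C(=O)COc1ccc(C)cc1`: 21300 nM
compound 2, `O=C(COc1ccc2c(c1)CCC2)N(Cc1cccs1)c1ccn[nH]1`: 0.001 nM
compound 3, `Cc1ccc(OCC(=O)N(Cc2cccs2)C2CC2)cc1`: 8 nM

Three compounds share a core built around an aryloxy acetamide, and all three were tested in an assay on HEK293 cells for agonist activity at transient receptor potential cation channel subfamily M member 8 (Homo sapiens), read by fluorescence and calcium flux, with a stated time of 15 min; on this read-out lower numbers stand for an effect already at smaller amounts and higher numbers for an effect only at larger amounts of compound. Compound 1 gives 21300 nM, the highest of the three numbers. Compound 3 gives 8 nM, a far lower number, and compound 2 gives 0.001 nM, lower still; both of these gaps lie well beyond the scatter of the method, so compound 1 is the weakest of the three by a wide margin.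

Compound 4, `CCN(Cc1cc[nH]c1)C(=O)COc1ccc(C)cc1`, has not yet been measured. It differs from compound 1 in one place: 1H-pyrrol-3-yl in place of 1-methyl-1H-pyrrol-2-yl on a saturated chain carbon bound to an amide-type nitrogen. Among the measured compounds shown here, nothing among the measured compounds shows how this particular exchange plays out, since compounds 2 and 3 differ from compound 1 at several places at once. With no guide, a step of a 1.4-fold lower number from compound 1 to compound 4 (0.15 log units; within the scatter) is expected, meaning no shift beyond the scatter, and compound 4 is estimated at 15000 nM, within 4000 nM to 60000 nM.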

Compound 4, half-maximal effective concentration: 21800 nM
Compound 4: the middle estimate sits 1.5-fold (0.16 log units) below what was measured; the range from low to high includes it.
By their numbers in this assay, from the lowest: compound 2; then compound 3; then compounds 1 and 4 (each within the scatter of the next).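

In this assay, putting 1H-pyrrol-3-yl in place of 1-methyl-1H-pyrrol-2-yl on a saturated chain carbon bound to an amide-type nitrogen gives a 1.0-fold higher number from compound 1 to compound 4 (0.01 log units; within the scatter) and so leaves the number unchanged within the scatter. Among the compounds shown here, this is the first comparison here that isolates a single place, and it shows that this exchange, which removes a heavy atom and brings in a hydrogen-bond donor in place of a hydrogen-bond acceptor, does not shift the read-out. Nothing available explains this absence of a shift.

As far as these compounds go, only these two five-membered rings have been compared at this place, so it remains open whether a different group there, such as a phenyl ring, a primary amine or a carboxylic acid, would move the number. Compounds 2 and 3 differ from compound 1 at several places at once, so they do not show which change accounts for their much lower numbers.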